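The source may hold more compounds than are shown below. What is called first, only, known or untested is meant among the compounds shown, and "the series" means these compounds.

In a functional assay on MCF7 cells (Homo sapiens) for inhibition, read by MTT assay, with a stated time of 24 h (on this read-out lower numbers stand for stronger inhibition of growth and higher numbers for weaker inhibition of growth), compound 1 `COc1cccc(C(=O)n2c(-c3cn(C)c4ccccc34)nc3ccccc32)c1` gives 15700 nM, compound 2 `Cn1cc(-c2nc3ccccc3n2C(=O)c2ccccc2)c2cc(Br)ccc21` gives 50300 nM and compound 3 `COc1ccccc1C(=O)n1c(-c2cn(C)c3ccc(Br)cc23)nc2ccccc21` gives 36200 nM. Compound 3 thus lies within the scatter of compound 2 and beyond the scatter above compound 1. Compound 4 `COc1cccc(C(=O)n2c(-c3cn(C)c4ccc(Br)cc34)nc3ccccc32)c1` differs from compound 3 in one place: 3-methoxyphenyl in place of 2-methoxyphenyl on a carbonyl carbon. Among the compounds with values here, the one measured step bearing on this, a 1.4-fold lower number from compound 2 to compound 3 (0.14 log units; within the scatter), came with methoxy in place of hydrogen on an aromatic carbon and stayed within the scatter. Compound 1, at 15700 nM, also carries 3-methoxyphenyl on a carbonyl carbon, which tilts the expectation slightly towards a lower number. The expected change is a 1.2-fold lower number from compound 3 to compound 4 (0.10 log units; within the scatter), so no shift beyond the scatter is anticipated. Compound 4 is estimated at 29000 nM, with an expected range from 13000 nM to 62000 nM.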

Compound 4, concentration for 50% growth inhibition: 18200 nM
Beside the measured number, compound 4's estimate is 1.6-fold (0.20 log units) above it, and the stated range covers the measured number.
By their numbers in this assay, from the lowest: compounds 1, 4, 3 and 2 (each within the scatter of the next, the first and the last beyond it).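

In this assay, 3-methoxyphenyl in place of 2-methoxyphenyl on a carbonyl carbon gives a 2.0-fold lower number from compound 3 to compound 4 (0.30 log units; within the scatter) and so does not separate the two methoxy placements. With 3-methoxyphenyl, methoxy in place of hydrogen gives a 2.8-fold lower number from compound 2 to compound 4 (0.44 log units; beyond the scatter) and passes the scatter, whereas with 2-methoxyphenyl it gave a 1.4-fold lower number from compound 2 to compound 3 (0.14 log units; within the scatter) and did not. Bromo in place of hydrogen gives a 1.2-fold higher number from compound 1 to compound 4 (0.06 log units; within the scatter) and makes no clear difference with 3-methoxyphenyl present. Still open, as far as these compounds go, is how an amine or a carboxylic acid in place of the methoxy would read out in this assay on the same core. No available evidence accounts for these steps.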